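The source may report more compounds than this note shows. Statements on the series, on what has been measured and on what is new or still open speak of the compounds shown alone.

Compound 1 `Cc1cc(C)cc(SCc2ccc(/C=C/C(=O)Nc3ccccc3N)cc2)c1`: 3.39%
Compound 2 `CCc1ccc(SCc2ccc(C(=O)Nc3ccccc3N)cc2)cc1`: 71%

In a functional assay on HeLa cells (Homo sapiens) for inhibition, read by CCK-8 assay, with a stated time of 72 h, tested at 8 uM (on this read-out higher numbers stand for more inhibition of growth at the one concentration tested and lower numbers for less inhibition of growth), compound 1 gives 3.39%, and compound 2 stands highest of the two measured compounds with 71%. The gap between these two lies beyond the scatter. The two differ in more than one place, so their gap does not isolate any single structural change. Compound 3 `CC(C)(C)c1ccc(SCc2ccc(C(=O)Nc3ccccc3N)cc2)cc1` retains the shared core of compound 2 and carries tert-butyl in place of ethyl on an aromatic carbon, para to a large group. Going by the values given here, with no measured single-change step to serve as a guide, the expectation rests on compound 2 at 71% and on the limited nature of this change. The expected result is a slight fall that stays within the scatter, an estimated step of a number 7 percentage points lower from compound 2 to compound 3 (within the scatter). For compound 3 the estimate is 64%, with an expected range of 40% to 85%.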

Compound 3, percent growth inhibition at one concentration: 40.2%
Estimate against measurement, compound 3: 23.8 percentage points above; low and high end bracket the measured number.
By their numbers in this assay, from the lowest: compound 1; then compound 3; then compound 2.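

In this assay, going by these compounds alone, tert-butyl in place of ethyl on an aromatic carbon, para to a large group, gives a step of a number 30.8 percentage points lower from compound 2 to compound 3 (beyond the scatter), the first comparison in this set that isolates a single change. It shows that this position is sensitive to which alkyl group it carries, even though neither group has hydrogen-bond donors, hydrogen-bond acceptors or a net charge, and that compound 3 still retains 40.2% with the bulkier substituent in place. Nothing available accounts for the size of this step.

On these data alone, two groups at one position cannot define a trend, so it remains open whether methyl or a longer chain such as n-propyl would fall on the same line. It is also unknown how an amine or a carboxylic acid at this position would read out.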